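Terminal ring swap on a phosphonate-bearing aryl ether tail

The source may hold more compounds than are shown below. What is called first, only, known or untested is meant among the compounds shown, and "the series" means these compounds.

Measured compounds:
compound 1 `C[C@](N)(COP(=O)(O)O)C(=O)Nc1ccc(OCCc2ccc(-c3cccs3)cc2)cc1` — "not determined" (no result reported) in an assay on isolated protein for displacement of a labelled ligand from sphingosine 1-phosphate receptor 5 (Homo sapiens); on this read-out lower numbers stand for stronger inhibition and higher numbers for weaker inhibition
compound 2 `C[C@](N)(COP(=O)(O)O)C(=O)Nc1ccc(OCCCCCc2ccccc2)cc1` — 2.9 nM

Among the compounds with values here, compound 2 is the only compound with a number in this assay; compound 1 carries no result, so compound 2 stands alone and cannot be ranked against anything. In this assay compound 2 gives 2.9 nM.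

Compound 3 `C[C@](N)(COP(=O)(O)O)C(=O)Nc1ccc(OCCCCC2CCCCC2)cc1` differs from compound 2 in one place: cyclohexyl in place of benzyl on a saturated chain carbon, four bonds along the chain from an oxygen on an aromatic ring. Within the data shown here, no measured pair shows this kind of change, so no step between measured compounds can guide the expectation, and only the single value of compound 2 is available as an anchor.

For compound 3 the expected step is a 1.6-fold higher number from compound 2 to compound 3 (0.19 log units; within the scatter), a small movement toward weaker displacement that may not rise beyond the scatter. Compound 3 is therefore estimated at 4.5 nM, with a range from 1.2 nM to 18 nM.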

Compound 3, half-maximal inhibitory concentration: 26.2 nM
Compound 3: the middle estimate sits 5.8-fold (0.77 log units) below what was measured; measured number outside the range, above it.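

Replacing benzyl with cyclohexyl on a saturated chain carbon, four bonds along the chain from an oxygen on an aromatic ring, gives a 9.0-fold higher number from compound 2 to compound 3 (0.96 log units; beyond the scatter) in this assay. This first readable step shows that this position is sensitive to the change from an aromatic to a non-aromatic six-membered ring of carbon only, although compound 3 still reads 26.2 nM and so remains in the low nanomolar range. Nothing shown here explains the loss.

The compounds shown leave open how a pyridyl or cyclopentyl ring would read at this position, and whether a longer chain would alter the step. They also leave open whether the same swap would have a similar effect on other tails, since compound 1 offers no number for comparison.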